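The compounds below may be only part of what the source reports. "The series", "measured", "known", "first", "only" and "open" are said of these compounds alone.

Compound 1, `CCc1ccccc1-c1nc(N)nc(N)n1`: 20%
Compound 2, `Nc1nc(N)nc(-c2cc(Br)ccc2Cl)n1`: 86%
Compound 3, `Nc1nc(N)nc(-c2ccccc2I)n1`: -7%

For the measured compounds named here, the three compounds measured so far share the core of compound 1 and differ only in what sits on the six-membered aromatic ring of carbon only. In a functional assay on the whole organism with Rattus norvegicus as the target, at a dose of 20 mg/kg by the intraperitoneal route (a lower number here means less inhibition, a higher number more inhibition at the dose given (going by the name of the read-out)), compound 1 gives 20%, compound 2 gives 86%, and compound 3 gives -7%, the lowest of the three numbers. Compound 1 is its nearest neighbour, compound 2 its furthest. Going by the values given here, the only single-change step measured runs a number 27 percentage points lower from compound 1 to compound 3 (beyond the scatter), so iodo in place of ethyl on the aromatic carbon went with a modest fall in inhibition.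

Compound 4, `Nc1nc(N)nc(-c2ccccc2Cl)n1`, has not yet been measured. It differs from compound 3 in one place: chloro in place of iodo on an aromatic carbon. A single iodine leaves and a single chlorine enters at the same aromatic carbon. Among the compounds with values here, no measured step exchanges one halogen for another, so the step from compound 1 to compound 3 is the only guide, and it bears only loosely here. Compound 2 also carries chloro on its ring, alongside bromo, and its value is high. An upward step is therefore expected, of uncertain size. Compound 4 is estimated at 40%, ranging from 0% to 80%. That expectation amounts to a step of a number 47 percentage points higher from compound 3 to compound 4 (beyond the scatter).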

Compound 4, a percentage reported as inhibition, in the whole organism at one dose (the size of the read-out at that dose, not a potency) in the Rattus norvegicus assay: 36%
Compound 4: the middle estimate sits 4 percentage points above what was measured; low and high end bracket the measured number.
By their numbers in the Rattus norvegicus assay, from the lowest: compound 3; then compound 1; then compound 4; then compound 2.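

In the Rattus norvegicus assay, the exchange of one halogen for another on this aromatic carbon, ortho to a group of 8 heavy atoms, is far from neutral: the result is a number 43 percentage points higher from compound 3 to compound 4 (beyond the scatter), and there is also a number 16 percentage points higher from compound 1 to compound 4 (beyond the scatter), so among iodo, ethyl and chloro at this carbon, chloro goes with the most inhibition. The bromo of compound 2 also counts for much even with chloro in place, since the Rattus norvegicus assay shows a number 50 percentage points lower from compound 2 to compound 4 (beyond the scatter). In a physicochemical assay for lipophilicity (on this read-out lower numbers stand for lower lipophilicity and higher numbers for higher lipophilicity), compound 3 gives 1.41 and compound 4 gives 1.19, two numbers within the usual scatter of each other, and nothing available explains the large step in inhibition.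

For the compounds shown here, only three groups have been compared at this carbon, so it remains open how fluoro, bromo, a methoxy group or an amine would behave there. From the compounds shown here alone, it is also open whether adding bromo to the ring would give a similar rise in inhibition with iodo or ethyl in place of chloro.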